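Thiophene in Place of Methoxyphenyl on a Dienone Chain

A few compounds are considered here, and "the series" means these few. Any claim that something is new, unique, unknown or untested is made for them only; others in the source may bear on it.

Of the compounds shown here, three have been measured in a functional assay on HCT-116 cells (Homo sapiens) for inhibition, read by sulforhodamine B assay, with a stated time of 48 h, tested at 50 uM; on this read-out higher numbers stand for more inhibition of growth at the one concentration tested and lower numbers for less inhibition of growth. Compound 1 `COc1cc(/C=C/C(=O)/C=C/c2cccs2)ccc1OCc1cn(CCOc2cc(=O)oc3ccccc23)nn1` gives 71%, compound 3 `COc1cccc(/C=C/C(=O)/C=C/c2ccc(OCc3cn(CCOc4cc(=O)oc5ccccc45)nn3)c(OC)c2)c1` gives 70%, and compound 2 `COc1cccc(/C=C/C(=O)/C=C/c2ccc(OCc3cn(CCCCCOc4cc(=O)oc5ccccc45)nn3)c(OC)c2)c1` gives 36%, the lowest of the three, its steps to the others lying beyond the scatter. Compound 1 and compound 3 differ in one place: thiophen-2-yl in place of 3-methoxyphenyl on a double-bonded chain carbon bound to a double-bonded chain carbon. That change brings a number 1 percentage points higher from compound 3 to compound 1 (within the scatter). Compound 2 and compound 3 differ in more than one place; the difference between the two cores is not broken down here. Compound 4 `COc1cc(/C=C/C(=O)/C=C/c2cccs2)ccc1OCc1cn(CCCCCOc2cc(=O)oc3ccccc23)nn1` is not yet measured and differs from compound 2 by thiophen-2-yl in place of 3-methoxyphenyl on a double-bonded chain carbon bound to a double-bonded chain carbon, the same change at the same place. Because the step of a number 1 percentage points higher from compound 3 to compound 1 (within the scatter) stays within the scatter, the expected step for compound 4 is a number 2 percentage points higher from compound 2 to compound 4 (within the scatter) in this assay. Compound 4 is estimated at 38%, between 22% and 55%.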

Compound 4, percent growth inhibition at one concentration: 31%
Compound 4: middle estimate off by 7 percentage points, on the high side, and the stated range covers the measured number.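

On the core of compound 2, putting thiophen-2-yl in place of 3-methoxyphenyl gives a number 5 percentage points lower from compound 2 to compound 4 (within the scatter) in this assay. Set beside the same change on the core of compound 3, the step shows no detectable dependence on the core: the same change on two cores in this assay, a number 1 percentage points higher (within the scatter) from compound 3 to compound 1 and a number 5 percentage points lower (within the scatter) from compound 2 to compound 4, 6 percentage points apart, within the scatter of two such steps On these two cores, the swap leaves growth inhibition within the usual scatter, but two pairs tested at one concentration on one cell line do not show that this would hold on other cores or in other assays.

The compounds shown leave open how a different group at this place would behave, such as a phenyl ring carrying an amine or a carboxylic acid.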